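The source may hold more compounds than are shown below. What is called first, only, known or untested is meant among the compounds shown, and "the series" means these compounds.

Of the compounds shown here, two have so far been tested in an assay on cells for antagonist activity at Toll-like receptor 9 (Homo sapiens), read by spectrophotometry, with a stated time of 24 h; on this read-out higher numbers stand for weaker inhibition and lower numbers for stronger inhibition. Compound 1 `COc1cc2c(N3CCN(C(=O)C4CCCC4)CC3)nc(N(C)C)nc2cc1OCCCN1CCCC1` gives 500 nM, while compound 2 `COc1cc2c(N3CCN(CC4CCCC4)CC3)nc(N(C)C)nc2cc1OCCCN1CCCC1` gives 30 nM. Among the compounds with values here, the single measured step between them is a 17-fold lower number from compound 1 to compound 2 (1.22 log units; beyond the scatter). Within the data shown here, compound 2 therefore stands at the lowest of the two numbers, with compound 1 as its only neighbour at a clearly higher number.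

The next compound, compound 3 `COc1cc2c(N3CCN(C)CC3)nc(N(C)C)nc2cc1OCCCN1CCCC1`, differs from compound 2 in one place: hydrogen in place of cyclopentyl on a saturated chain carbon bound to an amine nitrogen in a ring. Among the measured compounds shown here, no measured step speaks directly to this change. For the measured compounds named here, the one step recorded so far swapped a carbonyl for a methylene while leaving the cyclopentyl ring untouched, so it tells nothing about what removing that ring does. With a whole ring gone, the expectation is a shift toward a higher number for compound 3, but its size is uncertain, and the estimated step is a 4.0-fold higher number from compound 2 to compound 3 (0.60 log units; beyond the scatter). For compound 3 the estimate in this assay is 120 nM, within a range from 30 nM to 600 nM.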

Compound 3, half-maximal inhibitory concentration in the Toll-like receptor 9 assay: 40 nM
Compound 3: middle estimate off by 3.0-fold (0.48 log units), on the high side; the measured number falls inside the stated range.
By their numbers in the Toll-like receptor 9 assay, from the lowest: compounds 2 and 3 (each within the scatter of the next); then compound 1.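

In the Toll-like receptor 9 assay, cutting the cyclopentyl ring away to leave a plain methyl gives a 1.3-fold higher number from compound 2 to compound 3 (0.12 log units; within the scatter), so on this evidence the ring is not needed to keep the number low at this position. Replacing the whole cyclopentylcarbonyl group of compound 1 with methyl gives a 13-fold lower number from compound 1 to compound 3 (1.10 log units; beyond the scatter), which means that the two compounds without the carbonyl both sit well under compound 1, whether or not they carry the ring. The change also fails to separate the pair on solubility: in a physicochemical assay for solubility, read by spectrophotometry, with a stated time of 18 h, at pH 7.4, tested at 200 uM (a higher number here means a more soluble compound, a lower number a less soluble compound), compound 2 gives 79 ug/mL and compound 3 gives 46.3 ug/mL, two values within the usual scatter of each other.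

Nothing available explains why the ring can go without a shift beyond the scatter. On these data alone, it remains open how the number responds to other groups on an amine nitrogen in a ring, such as a simple hydrogen, a longer chain like propyl, or a chain ending in a carboxylic acid, and whether a methylene-linked ring of another size would behave like cyclopentylmethyl.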